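The source may hold more compounds than are shown below. What is called first, only, known or untested is meant among the compounds shown, and "the series" means these compounds.

Working notes on the series: in an ADME assay on L6 cells (Rattus norvegicus) for cytotoxicity, read by resazurin assay, with a stated time of 72 h (a lower number here means a stronger inhibitor, a higher number a weaker inhibitor), compound 1 (`OC(c1ccc(Cl)cc1)(c1ccc(Br)cc1)c1cncnc1`) gives 58700 nM and compound 2 (`OC(c1ccc(Cl)cc1)(c1ccc(Br)cc1)c1cccnc1`) gives 57000 nM, so compound 2 stands within the scatter of compound 1. Compound 3 (`COc1ccc(C(O)(c2ccc(Cl)cc2)c2cccnc2)cc1`) differs from compound 2 by one change: methoxy in place of bromo on an aromatic carbon. Going by the values given here, the only measured step, a 1.0-fold lower number from compound 1 to compound 2 (0.01 log units; within the scatter), lies at a different place, so it offers only weak guidance and no measured step covers this exchange. The estimated step in this assay is a 1.1-fold higher number from compound 2 to compound 3 (0.06 log units; within the scatter), with none expected beyond the scatter. Compound 3 is expected at 65000 nM, with an estimated range of 30000 nM to 140000 nM.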

Compound 3, half-maximal inhibitory concentration: 68100 nM
For compound 3 the middle estimate is 1.0-fold (0.02 log units) below the measured one; the measured number falls inside the stated range.
By their numbers in this assay, from the lowest: compounds 2, 1 and 3 (each within the scatter of the next).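

In this assay, methoxy in place of bromo on the aromatic carbon para to a large group gives a 1.2-fold higher number from compound 2 to compound 3 (0.08 log units; within the scatter). Going by these compounds alone, this is the first step read at this position, and it shows that exchanging bromo for methoxy, with its hydrogen-bond acceptor and additional heavy atom, leaves the number within the scatter. No available evidence bears on this result. The compounds shown leave open whether any group at this position moves the number beyond the scatter. An amine or a carboxylic acid here remains an untested comparison within the compounds shown.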